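This account rests on a few compounds, and the source may have more. Where it says the series, first, only, none or still open, it means among the compounds named here.

Notes on the series. In an assay on IM-9 cells for displacement of a labelled ligand from Substance-P receptor (Homo sapiens), read by scintillation counting, with a stated time of 30 min (on this read-out lower numbers stand for stronger inhibition and higher numbers for weaker inhibition), compound 1 `CC(=O)N1CCC(C(=O)N2CC[C@H](C(=O)N(C)Cc3cc(C(F)(F)F)cc(C(F)(F)F)c3)[C@@H](c3ccc(F)cc3C)C2)CC1` gives 0.047 nM. Compound 2 `CC(=O)N1CCC(C(=O)N2CC[C@H](C(=O)N(C)Cc3cc(C(F)(F)F)cc(C(F)(F)F)c3)[C@@H](c3ccccc3C)C2)CC1` gives 0.032 nM in this assay, and compound 3 `CC(=O)N1CCC(C(=O)N2CC[C@H](C(=O)N(C)Cc3cc(C(F)(F)F)cc(C(F)(F)F)c3)[C@@H](c3ccccc3C(C)C)C2)CC1` gives 0.21 nM. Of these three numbers compound 1 stands second highest, nearest to compound 2 and furthest from compound 3: a 1.5-fold lower number from compound 1 to compound 2 (0.17 log units; within the scatter), a 4.5-fold higher number from compound 1 to compound 3 (0.65 log units; beyond the scatter), a 6.6-fold higher number from compound 2 to compound 3 (0.82 log units; beyond the scatter). Every measured step alters only the aryl group on the saturated ring carbon.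

Compound 4 `CNC(=O)C(=O)N1CC[C@H](C(=O)N(C)Cc2cc(C(F)(F)F)cc(C(F)(F)F)c2)[C@@H](c2ccc(F)cc2C)C1` differs from compound 1 at another place: methylcarbamoyl in place of 1-acetylpiperidin-4-yl on a carbonyl carbon. Among the measured compounds shown here, no measured step touches this carbonyl carbon, and the aryl group of compound 4 is that of compound 1, so none of the three steps bears on the change directly; the only guide is that the shared core has tolerated the aryl variations with at most modest shifts. A modest rise, not firmly beyond the scatter, is expected here. Compound 4 is expected to give 0.15 nM in this assay, with a range from 0.03 nM to 0.8 nM. The expected step is a 3.2-fold higher number from compound 1 to compound 4 (0.50 log units; beyond the scatter).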

Compound 4, half-maximal inhibitory concentration: 0.11 nM
Estimate against measurement, compound 4: 1.4-fold (0.13 log units) above; the measured number falls inside the stated range.
By their numbers in this assay, from the lowest: compounds 2 and 1 (each within the scatter of the next); then compounds 4 and 3 (each within the scatter of the next).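

In this assay, among the compounds shown here, methylcarbamoyl in place of 1-acetylpiperidin-4-yl on the carbonyl carbon gives a 2.3-fold higher number from compound 1 to compound 4 (0.37 log units; beyond the scatter), the first measured change at this position and a modest one. The position therefore accepts a group with no ring and far fewer heavy atoms, now carrying a hydrogen-bond donor, and compound 4 still gives 0.11 nM. Nothing shown explains the step.

With the ring, the size and the amide hydrogen all changing together, this single pair cannot separate their contributions. Going by these compounds, a dimethylcarbamoyl group or an unacetylated piperidin-4-yl with its free amine on the same carbonyl carbon remains open, as does whether the step holds with the other aryl groups of the series.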